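Swapping a furan for a nitrophenyl on a chalcone-linked flavone

The source may hold more compounds than are shown below. What is called first, only, known or untested is meant among the compounds shown, and "the series" means these compounds.

Measured so far:
Compound 1, `COc1cc(OC)c2c(=O)c(OCCCOc3ccccc3/C=C/C(=O)/C=C/c3cccc([N+](=O)[O-])c3)c(-c3cc(OC)c(OC)c(OC)c3)oc2c1`: 5730 nM
Compound 2, `COc1cc(OC)c2c(=O)c(OCCCCOc3ccccc3/C=C/C(=O)/C=C/c3ccco3)c(-c3cc(OC)c(OC)c(OC)c3)oc2c1`: 7900 nM

Both compounds were tested in a functional assay on MGC-803 cells (Homo sapiens) for antiproliferative activity, read by MTT assay, with a stated time of 48 h; on this read-out lower numbers stand for stronger inhibition and higher numbers for weaker inhibition. Compound 1 gives 5730 nM and compound 2 gives 7900 nM; compound 2 holds the higher of the two numbers, but the gap to compound 1 lies within the usual scatter, so the two read as alike.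

Compound 3, `COc1cc(OC)c2c(=O)c(OCCCCOc3ccccc3/C=C/C(=O)/C=C/c3cccc([N+](=O)[O-])c3)c(-c3cc(OC)c(OC)c(OC)c3)oc2c1`, has not been measured. It differs from compound 2 in one place: 3-nitrophenyl in place of furan-2-yl on a double-bonded chain carbon bound to a double-bonded chain carbon. Compound 1 already carries this same 3-nitrophenyl group, on a shorter linker, and its value in this assay sits close to that of compound 2. No clear direction is therefore expected from the change; the step from compound 2 to compound 3 is estimated as a 1.4-fold lower number from compound 2 to compound 3 (0.13 log units; within the scatter), within the scatter. For compound 3 the expected value in this assay is 5800 nM, with a range from 2500 nM to 13000 nM.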

Compound 3, half-maximal inhibitory concentration: 5060 nM
The estimate for compound 3 lay 1.1-fold (0.06 log units) above the measured number; the measured number falls inside the stated range.
By their numbers in this assay, from the lowest: compounds 3, 1 and 2 (each within the scatter of the next).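

In this assay, putting 3-nitrophenyl in place of furan-2-yl on a double-bonded chain carbon bound to a double-bonded chain carbon gives a 1.6-fold lower number from compound 2 to compound 3 (0.19 log units; within the scatter). Within the data shown here, this pair offers the first direct comparison of the two groups on an otherwise identical molecule. At this place, a five-membered aromatic ring with one hetero atom and a six-membered aromatic ring of carbon only, carrying a nitro group, read as alike, so this change makes no clear difference here, and nothing available accounts for that result.

The compounds shown leave open whether a phenyl ring bearing an amine or a carboxylic acid at this place would shift the number beyond the scatter. They also leave open whether an unsubstituted phenyl ring would read like these two groups.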